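The source may report more compounds than this note shows. Statements on the series, on what has been measured and on what is new or still open speak of the compounds shown alone.

Measured so far:
- compound 1 `FC(F)(F)c1ccc(-c2ccc(-c3ccc(-c4nc5ccccc5[nH]4)cc3)cc2)cc1`: 47200 nM
- compound 2 `Oc1cccc2[nH]c(-c3ccc(-c4ccc(-c5ccc(F)cc5)cc4)cc3)nc12`: 6920 nM

The measurements come from a functional assay on KB cells (Homo sapiens) for inhibition, read by sulforhodamine B assay; on this read-out higher numbers stand for weaker inhibition of growth and lower numbers for stronger inhibition of growth. In this test, compound 2 gives 6920 nM, the lower of the two numbers and therefore the stronger inhibition of growth. Compound 1 gives 47200 nM, a gap beyond the usual scatter of repeated measurements.

The next compound to be tested is compound 3 `Oc1cccc2[nH]c(-c3ccc(-c4ccc(-c5ccc(C(F)(F)F)cc5)cc4)cc3)nc12`. It differs from compound 2 in one place, where trifluoromethyl stands in place of fluoro on an aromatic carbon, para to a large group: trifluoromethyl in place of fluoro on an aromatic carbon.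

Within the data shown here, no measured pair shows this exchange, so the data give no direct size for the step. The expectation therefore starts from compound 2 at 6920 nM, and a modest move toward a higher number, meaning weaker inhibition, seems most likely. A step too small to stand out from the scatter remains possible.

The expected change is a 1.6-fold higher number from compound 2 to compound 3 (0.20 log units; within the scatter). For compound 3, the estimated value is 11000 nM, with an expected range of 4000 nM to 35000 nM.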

Compound 3, concentration for 50% growth inhibition: 4320 nM
For compound 3 the middle estimate is 2.5-fold (0.41 log units) above the measured one; the range from low to high includes it.
By their numbers in this assay, from the lowest: compounds 3 and 2 (each within the scatter of the next); then compound 1.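

In this assay, moving from 4-fluorophenyl to 4-(trifluoromethyl)phenyl gives a 1.6-fold lower number from compound 2 to compound 3 (0.20 log units; within the scatter), so at this place, on an aromatic carbon and para to a large group, the two groups cannot be told apart by growth inhibition. Among these compounds, compound 3 also forms the first measured pair that isolates hydroxy in place of hydrogen on an aromatic carbon: the step is an 11-fold lower number from compound 1 to compound 3 (1.04 log units; beyond the scatter), which is beyond the scatter and shows that this single change goes with clearly stronger inhibition of growth when trifluoromethyl is present. Nothing available explains why either step has the size it has.

From the compounds shown here alone, only fluoro and trifluoromethyl have been seen at the para place, so it remains open whether a very different group there, such as an amine or a carboxylic acid, would also leave the number unchanged. Going by these compounds, it is also open whether the gain seen with hydroxy depends on that group itself, since a methoxy group or an amine at the same carbon could separate the role of the hydroxy group from that of any substituent there.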